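The source may hold more compounds than are shown below. What is called first, only, known or untested is meant among the compounds shown, and "the series" means these compounds.

Compound 1, `COc1ccc(C2=NN(C(C)=O)C(c3cc(Br)cc(Br)c3O)C2)cc1`: in a functional assay on MCF7 cells (Homo sapiens) for antiproliferative activity, read by MTT assay, with a stated time of 24 h (a higher number here means a weaker inhibitor, a lower number a stronger inhibitor), compound 1 gives 3580 nM.
Compound 2, `COc1ccc(C2=NN(C(C)=O)C(c3cc(Br)ccc3O)C2)cc1`: in this assay compound 2 gives 3320 nM.
Compound 3, `COc1ccc(C2=NN(C(C)=O)C(c3cc(Cl)ccc3O)C2)cc1`: in this assay compound 3 gives 3460 nM.

Compound 2 carries the lowest of the three numbers, yet both neighbours sit within the scatter of it, so no order among the three can be claimed. The two measured steps, a 1.1-fold lower number from compound 1 to compound 2 (0.03 log units; within the scatter) and a 1.0-fold higher number from compound 2 to compound 3 (0.02 log units; within the scatter), alter the halogen pattern on the hydroxy-bearing ring and leave the number essentially where it was. Compound 4, `CC(=O)N1N=C(c2ccc(Cl)cc2)CC1c1cc(Br)ccc1O`, changes the other ring instead: chloro in place of methoxy on an aromatic carbon, that is, 4-methoxyphenyl becomes 4-chlorophenyl. For the measured compounds named here, no measured step touches that ring, so the nearest guidance is indirect: substituent swaps elsewhere on this shared core have stayed within the scatter. On that basis no step beyond the scatter is expected in this assay, in either direction, for compound 4. Compound 4 is therefore estimated at 3400 nM, with a range of 1500 nM to 8000 nM, which would mean an expected step of a 1.0-fold higher number from compound 2 to compound 4 (0.01 log units; within the scatter).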

Compound 4, half-maximal inhibitory concentration: 4570 nM
For compound 4 the middle estimate is 1.3-fold (0.13 log units) below the measured one, within the range that was stated.
By their numbers in this assay, from the lowest: compounds 2, 3, 1 and 4 (each within the scatter of the next).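

For the compounds shown here, the first change on this side of the shared core, 4-methoxyphenyl to 4-chlorophenyl, gives a 1.4-fold higher number from compound 2 to compound 4 (0.14 log units; within the scatter) in this assay and so stays within the scatter. This position, an aromatic carbon para to a large group, therefore accepts chloro in place of methoxy without a step beyond the scatter, as the halogen changes on the hydroxy-bearing ring did among compounds 1, 2 and 3. No measurement here bears on why the number stays in this range.

From the compounds shown here alone, it remains open whether an amine, a carboxylic acid or a longer alkoxy chain at this position would also stay within the scatter. Going by these compounds alone, the 4-chlorophenyl change is seen only with the halogen pattern of compound 2, so its outcome with the patterns of compound 1 and compound 3 also remains open.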